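The source may report more compounds than this note shows. Statements on the series, on what has been measured and on what is new or still open speak of the compounds shown alone.

Measured so far:
compound 1 `O=C(CCCCCCc1cn(-c2ccccc2-c2ccccc2)nn1)NCc1cccnc1` – 98%
compound 2 `O=C(CCc1cccnc1)NCCCCCc1cn(-c2ccccc2-c2ccccc2)nn1` – 54%
compound 3 `O=C(CCCCCCCCc1cn(-c2cnc3ccccc3c2)nn1)NCc1cccnc1` – 102%

In a functional assay on SH-SY5Y cells (Homo sapiens) for cytotoxicity, read by MTT assay, with a stated time of 48 h, tested at 1 uM (a higher number here means a weaker effect of the compound at the concentration tested, a lower number a stronger effect), compound 1 gives 98% and compound 3 gives 102%, while compound 2 gives 54%. Compound 2 therefore stands lowest of the three, which in this read-out means the strongest effect, and its steps to compound 1 and to compound 3 are both beyond the scatter.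

Compound 4 `O=C(Cc1cccnc1)NCCCCCc1cn(-c2ccccc2-c2ccccc2)nn1` differs from compound 2 in one place: pyridin-3-yl in place of (pyridin-3-yl)methyl on a saturated chain carbon bound to a carbonyl carbon. Going by the values given here, the one measured step, a number 44 percentage points lower from compound 1 to compound 2 (beyond the scatter), involved a far larger rearrangement, moving the pyridine-bearing part from one end of the chain to the other, so it bears only loosely on this smaller change. Among the compounds with values here, no measured pair tests shortening the chain between the carbonyl and the pyridine by a single carbon.

With so little to go on, the expected step of a number 11 percentage points higher from compound 2 to compound 4 (beyond the scatter) from compound 2 is small, of uncertain direction, and may well fall within the scatter. Compound 4 is estimated at 65%, within a range from 40% to 95%.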

Compound 4, a percentage reported as activity, at one concentration (the size of the read-out at that concentration, not a potency): 99%
Compound 4: middle estimate off by 34 percentage points, on the low side; the whole stated range lies below it.
By their numbers in this assay, from the lowest: compound 2; then compounds 1, 4 and 3 (each within the scatter of the next).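

In this assay, the effect seen with compound 2 depends sharply on this position: pyridin-3-yl in place of (pyridin-3-yl)methyl on a saturated chain carbon bound to a carbonyl carbon gives a number 45 percentage points higher from compound 2 to compound 4 (beyond the scatter). The other new comparison, with (((pyridin-3-yl)methyl)carbonyl)amino in place of (((pyridin-3-yl)methyl)carbamoyl)methyl, gives a number 1 percentage points higher from compound 1 to compound 4 (within the scatter), so among these compounds that exchange alone brings no change, and the effect appears only with the 2-(pyridin-3-yl)ethyl group of compound 2. Nothing shown here accounts for the size of the step from the shorter group to the longer one.

As far as these compounds go, whether a longer chain between the carbonyl and the pyridine would keep the effect remains open. So does whether a phenyl ring or an amine could stand in place of the pyridine.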